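This account rests on a few compounds, and the source may have more. Where it says the series, first, only, none or still open, it means among the compounds named here.

Compound 3 `Cn1cc(SCc2nnc(SCc3cc(Cl)ccc3Cl)n2-c2c(Cl)cccc2Cl)c2ccccc21` stands at a limit of the assay rather than at a number: in a toxicity assay on HEK-293T cells (Homo sapiens) for cytotoxicity, read by CCK-8 assay, with a stated time of 48 h (on this read-out lower numbers stand for higher toxicity in this test and higher numbers for lower toxicity in this test), compound 3 shows > 100000 nM. Compound 1 `Cn1cc(SCc2nnc(SCc3ccccc3Cl)n2-c2c(Cl)cccc2Cl)c2ccccc21` gives 49600 nM in this assay. Compound 2 `Cn1cc(SCc2nnc(SCc3ccccc3OC(F)(F)F)n2-c2c(Cl)cccc2Cl)c2ccccc21` is again reported only as a limit, > 100000 nM. The known steps are an at least 2.0-fold higher number from compound 1 to compound 2 (0.30 log units; that floor lies within the scatter), an at least 2.0-fold higher number from compound 1 to compound 3 (0.30 log units; that floor lies within the scatter) and a step that the two limits leave unreadable from compound 2 to compound 3. Compound 4 `Cn1cc(SCc2nnc(SCc3ccc(Cl)cc3C(F)(F)F)n2-c2c(Cl)cccc2Cl)c2ccccc21` differs from compound 3 by 4-chloro-2-(trifluoromethyl)phenyl in place of 2,5-dichlorophenyl on a saturated chain carbon bound to a sulfur. Going by the values given here, the exchange of the whole benzyl group between compound 2 and compound 3 is the closest precedent, and it left the read-out unreadable at the limit; the step from compound 1 to compound 3 lies within the scatter. Compound 4 is therefore expected to sit near the same limit, a number no higher from compound 3 to compound 4 (the limit leaves the size open), with an estimated 100000 nM between 40000 nM and 250000 nM.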

Compound 4, half-maximal cytotoxic concentration: 56500 nM
Compound 4: the middle estimate sits 1.8-fold (0.25 log units) above what was measured; the range from low to high includes it.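

With 4-chloro-2-(trifluoromethyl)phenyl on the saturated chain carbon bound to a sulfur, this assay gives a number rather than a limit, showing that exchanging this whole group can bring the read-out back into range. The steps are an at least 1.7-fold lower number from compound 3 to compound 4 (0.24 log units; that floor lies within the scatter) and an at least 1.7-fold lower number from compound 2 to compound 4 (0.24 log units; that floor lies within the scatter) and, against the 2-chlorophenyl group, a 1.1-fold higher number from compound 1 to compound 4 (0.06 log units; within the scatter) for the third comparison. The first two steps are only floors: the limit of > 100000 nM in this assay, at which 2 of the 4 values shown sit. As far as these compounds go, whether any change here moves the read-out beyond the scatter stays open, as does the outcome with an amine or a carboxylic acid in place of this benzyl group.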